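Extending the primary amide of compound 1 on the amide nitrogen

The source may report more compounds than this note shows. Statements on the series, on what has been measured and on what is new or still open speak of the compounds shown alone.

Compound 1 `Cc1cc(C)cc(S(=O)(=O)c2c(C(N)=O)[nH]c3ccc(Cl)cc23)c1` carries a primary amide on the shared core. For the measured compounds named here, in an ADME assay on MT4 cells (Homo sapiens) for cytotoxicity, read by MTT assay, with a stated time of 5 days (on this read-out higher numbers stand for lower toxicity in this test and lower numbers for higher toxicity in this test), compound 1 gives 13000 nM, and of the two numbers known it is the one at the low end, although compound 2 `Cc1cc(C)cc(S(=O)(=O)c2c(C(=O)N[C@H]3CCN(Cc4n[nH]c(=O)n4C)C3)[nH]c3ccc(Cl)cc23)c1`, which gives 21500 nM in this assay, lies within the usual scatter of it, so the two compounds cannot be told apart on this read-out.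

Compound 3 `Cc1cc(C)cc(S(=O)(=O)c2c(C(=O)N[C@H]3CCN(CC(N)=O)C3)[nH]c3ccc(Cl)cc23)c1` is the compound to be measured. It differs from compound 1 in one place: 1-(carbamoylmethyl)pyrrolidin-3-yl in place of hydrogen on an amide-type nitrogen. Going by the values given here, no step between two measured compounds covers this exact change, but compound 2 also carries a larger substituent on the same amide nitrogen and sits within the scatter of compound 1.

On that basis, for compound 3 the step of a 1.3-fold higher number from compound 1 to compound 3 (0.12 log units; within the scatter) in this assay is expected to be small, if anything toward a higher number, and not beyond the scatter. Compound 3 is therefore estimated to give 17000 nM in this assay, with a range from 7000 nM to 40000 nM.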

Compound 3, half-maximal cytotoxic concentration: 28100 nM
For compound 3 the middle estimate is 1.7-fold (0.22 log units) below the measured one; measured number inside the range.
By their numbers in this assay, from the lowest: compounds 1, 2 and 3 (each within the scatter of the next, the first and the last beyond it).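

In this assay, for the compounds shown here, 1-(carbamoylmethyl)pyrrolidin-3-yl in place of hydrogen on the amide-type nitrogen gives a 2.2-fold higher number from compound 1 to compound 3 (0.33 log units; beyond the scatter), the first step on this nitrogen to pass beyond the scatter, though only modestly, so a substituent of this size here comes with no lower number in this test. Replacing a group of 7 heavy atoms that holds a five-membered aromatic ring with a group of 3 heavy atoms, on a saturated chain carbon bound to an amine nitrogen in a ring, gives a 1.3-fold higher number from compound 2 to compound 3 (0.12 log units; within the scatter), which stays within the scatter, so these two substituted amides cannot be told apart on this read-out. Nothing measured alongside these numbers accounts for either step.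

The compounds shown leave open whether the step from compound 1 goes with the five-membered ring itself or with what hangs on its nitrogen, since a bare pyrrolidin-3-yl group is not among them. On these data alone, how a carboxylic acid in place of the carbamoyl group, or a longer chain between that group and the ring nitrogen, would read in this assay also remains open.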